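Bromo for fluoro: working notes toward compound 4

This account rests on a few compounds, and the source may have more. Where it says the series, first, only, none or still open, it means among the compounds named here.

Measured so far:
Compound 1, `Cc1ccc2[nH]c(=O)c(-c3nc4cc([N+](=O)[O-])ccc4[nH]3)cc2c1`: in a functional assay on NCI-H460 cells (Homo sapiens) for cytotoxicity, read by MTT assay, with a stated time of 48 h (on this read-out higher numbers stand for weaker inhibition and lower numbers for stronger inhibition), compound 1 gives > 100000 nM, a limit of the assay rather than a number.
Compound 2, `COc1ccc2[nH]c(=O)c(-c3nc4cc(F)ccc4[nH]3)cc2c1`: in this assay compound 2 gives > 100000 nM, again only a limit.
Compound 3, `Cc1ccc2[nH]c(=O)c(-c3nc4cc(F)ccc4[nH]3)cc2c1`: in this assay compound 3 gives > 100000 nM, also a limit.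

Compound 2 therefore stands nowhere on a numerical scale in this assay; its value is a limit, and the two other values shown are limits as well. Compound 4, `COc1ccc2[nH]c(=O)c(-c3nc4cc(Br)ccc4[nH]3)cc2c1`, is the one still to be measured. It differs from compound 2 by bromo in place of fluoro on an aromatic carbon.

Going by the values given here, two measured steps touch the same region of the shared core. The step that the two limits leave unreadable from compound 1 to compound 3 and the step that the two limits leave unreadable from compound 2 to compound 3 are both left unreadable: the values at either end are limits. That is the whole picture: the limit of > 100000 nM in this assay, at which 3 of the 3 values shown sit. Among the compounds with values here, no measured step gives a direction or a size for the exchange of fluoro for bromo, and nothing beyond the scatter can be predicted in either direction.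

Compound 4 is thus expected to sit near 100000 nM, with a plausible range from 30000 nM to 300000 nM. For compound 4 the estimated step of a number no higher from compound 2 to compound 4 (the limit leaves the size open) is expected to be nil for practical purposes, with a limit the most likely report.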

Compound 4, half-maximal inhibitory concentration: > 100000 nM
Compound 4: a limit, no number; the forecaster's own chance of this, stated with the estimate: 75%; the middle value sits exactly at the limit.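

Neither compound 2 nor compound 4 gives a number in this assay, so no step can be read for bromo in place of fluoro on an aromatic carbon, and the series stays at one limit: the limit of > 100000 nM in this assay, at which 4 of the 4 values shown sit.

The compounds shown leave open whether any exchange on the shared core yields a measurable value in this assay, and of what size.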